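This account rests on a few compounds, and the source may have more. Where it says the series, first, only, none or still open, it means among the compounds named here.

Of the compounds shown here, three have so far been tested in a functional assay on the whole organism (strain Wistar Albino) for inhibition, with Rattus norvegicus as the target, read by paw edema, with a stated time of 1 h, at a dose of 20 mg/kg; on this read-out lower numbers stand for less inhibition and higher numbers for more inhibition at the one dose given (going by the name of the read-out). Compound 3 `Cc1occc1-c1nnc2n1NC(c1ccco1)S2` gives 16.4%, the highest of the three numbers. Going by the values given here, compound 1 `Cc1occc1-c1nnc2sc(-c3ccnc4ccccc34)nn12` gives 12.5%, a number that lies within the usual scatter of the one for compound 3, so the two cannot be told apart. Compound 2 `COc1ccc(Cl)c(-c2nnc3sc(Cc4c[nH]c5ccc(OC)cc45)nn23)c1` gives 6.1%, and its gap to compound 3 is beyond the scatter. Compound 4 `Cc1occc1-c1nnc2n1NC(c1ccc([N+](=O)[O-])o1)S2` has not yet been measured. It differs from compound 3 in one place: nitro in place of hydrogen on an aromatic carbon. Among the compounds with values here, no measured pair differing in a single place is available, so the size of such a step cannot be read from the data. In this assay the expected step is a number 1.6 percentage points higher from compound 3 to compound 4 (within the scatter), nothing beyond the scatter. Compound 4 is therefore estimated at 18%, in a range from 6% to 32%.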

Compound 4, a percentage reported as inhibition, in the whole organism at one dose (the size of the read-out at that dose, not a potency): 15.6%
Estimate against measurement, compound 4: 2.4 percentage points above; the measured number falls inside the stated range.
By their numbers in this assay, from the lowest: compounds 2, 1, 4 and 3 (each within the scatter of the next, the first and the last beyond it).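

Going by these compounds alone, the first single-place step comes from nitro in place of hydrogen on an aromatic carbon, next to the ring oxygen: in this assay it gives a number 0.8 percentage points lower from compound 3 to compound 4 (within the scatter). At this one dose, then, this position accepts a nitro group without a difference that can be told from scatter. No measurement available here offers an explanation for this result.

On these data alone, whether an amine, a carboxylic acid or a methyl group on the same carbon would also leave the number unmoved remains open. So does whether nitro would give the same result on a different core.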